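Cycloheptyl for 4-methylphenyl in the bombesin receptor subtype-3 series

The source may hold more compounds than are shown below. What is called first, only, known or untested is meant among the compounds shown, and "the series" means these compounds.

Compound 1 `O=C(O)c1ccccc1-c1ccc(CCc2ncc(CC3CCCCC3)[nH]2)cc1`: 41 nM in an in vitro functional assay on cells for agonist activity at Bombesin receptor subtype-3 (Homo sapiens), read by luminescence and calcium flux; on this read-out lower numbers stand for an effect already at smaller amounts and higher numbers for an effect only at larger amounts of compound
Compound 2 `Cc1ccc(Cc2cnc(CCc3ccc(-c4ccccc4C(=O)O)cc3)[nH]2)cc1`: 2660 nM

Of the compounds shown here, two have been measured so far. They share the same core and differ only in the group on a saturated chain carbon bound to an aromatic carbon. Compound 2 stands at the highest number of the two; its nearest neighbour is compound 1, from which it is separated by a 65-fold higher number from compound 1 to compound 2 (1.81 log units; beyond the scatter).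

Compound 3 `O=C(O)c1ccccc1-c1ccc(CCc2ncc(CC3CCCCCC3)[nH]2)cc1` has not yet been measured. It is drawn from compound 2 by a single change: cycloheptyl in place of 4-methylphenyl on a saturated chain carbon bound to an aromatic carbon. Among the measured compounds shown here, the only measured step that bears on this change is the one in the opposite sense, a 65-fold higher number from compound 1 to compound 2 (1.81 log units; beyond the scatter), where the same aromatic group entered in place of a non-aromatic ring of carbon only. Removing it again in compound 3 is therefore expected to bring the number back down by roughly that amount, with the change from a six- to a seven-membered ring left open by the data: the step is estimated as a 33-fold lower number from compound 2 to compound 3 (1.52 log units; beyond the scatter). For compound 3 the expected value in this assay is 80 nM, within 25 nM to 300 nM.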

Compound 3, half-maximal effective concentration: 88 nM
Estimate against measurement, compound 3: 1.1-fold (0.04 log units) below; measured number inside the range.
By their numbers in this assay, from the lowest: compound 1; then compound 3; then compound 2.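

In this assay the place on a saturated chain carbon bound to an aromatic carbon now has a second non-aromatic ring of carbon only, and cycloheptyl in place of 4-methylphenyl recovers most of the earlier loss (a 30-fold lower number from compound 2 to compound 3 (1.48 log units; beyond the scatter)). The low number is therefore not confined to cyclohexyl: among the three compounds, both non-aromatic rings give far lower numbers than the aromatic ring of compound 2. Ring size has a much smaller effect at this place, with a modest step that still lies beyond the scatter (a 2.1-fold higher number from compound 1 to compound 3 (0.33 log units; beyond the scatter)), and no measurement available here explains either step.

The three compounds leave open whether the high number of compound 2 belongs to the six-membered aromatic ring itself or to its methyl group, a question that plain phenyl would address. Also open, from the compounds shown here alone, is how far the ring series extends, whether to cyclopentyl or cyclooctyl, and whether a ring containing an amine, such as piperidinyl, or an open longer alkyl chain would fit this place as well as cyclohexyl.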